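This account rests on a few compounds, and the source may have more. Where it says the series, first, only, none or still open, it means among the compounds named here.

Measured so far in a functional assay on PC-3 cells (Homo sapiens) for inhibition; on this read-out higher numbers stand for weaker inhibition and lower numbers for stronger inhibition:

compound 1, `COc1cc2nc(N3CCN(C(=O)OCc4ccccc4)CC3)nc(N)c2cc1OC`, gives 63000 nM
compound 2, `COc1cc2nc(N3CCN(C(=O)c4ccc(C(F)(F)F)cc4)CC3)nc(N)c2cc1OC`, is reported only as a limit, > 100000 nM
compound 3, `COc1cc2nc(N3CCN(S(=O)(=O)c4cccc([N+](=O)[O-])c4)CC3)nc(N)c2cc1OC`, gives 32000 nM

Compound 3 holds the lowest of the two numbers shown; the nearest is compound 1, and the gap between them lies within the scatter. Compound 2 sits at the limit of > 100000 nM in this assay, at which 1 of the 3 values shown sits, so its value is a limit and not a number.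

One step between measured compounds is known: an at least 1.5-fold higher number from compound 1 to compound 2 (0.20 log units; that floor lies within the scatter), a change of the aryl group on a carbonyl carbon, with its floor within the scatter. It concerns a carbonyl-linked piperazine and says nothing direct about the sulfonyl-linked compounds.

Compound 4, `COc1cc2nc(N3CCN(S(=O)(=O)c4ccc(C(=O)O)cc4)CC3)nc(N)c2cc1OC`, is made from compound 3 by 4-carboxyphenyl in place of 3-nitrophenyl on a sulfonyl sulfur. No measured step changes a substituent on the sulfonyl aryl ring, so there is no shown precedent for the size or direction of this step. For the measured compounds named here, with the only measured step being small and on a different linker, no step beyond the scatter is expected in this assay , and the move from compound 3 to compound 4 is estimated as a 1.3-fold higher number from compound 3 to compound 4 (0.10 log units; within the scatter). Compound 4 is expected to give about 40000 nM, with a range from 12000 nM to 130000 nM, and the chance of a limit rather than a number is real given how close compound 3 already stands to the top of the range.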

Compound 4, half-maximal inhibitory concentration: 53000 nM
Compound 4: the middle estimate sits 1.3-fold (0.12 log units) below what was measured; the measured number falls inside the stated range.
By their numbers in this assay, from the lowest: compounds 3, 4 and 1 (each within the scatter of the next). At a limit, above all of these: compound 2.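

In this assay, the aryl group on a sulfonyl sulfur now has its first measured change, and it is small: a 1.7-fold higher number from compound 3 to compound 4 (0.22 log units; within the scatter). The swap of 3-nitrophenyl for 4-carboxyphenyl keeps the heavy-atom count of the group at 9 and brings in 1 hydrogen-bond donor where the leaving group has 0, yet compound 3 and compound 4 cannot be told apart in this read-out, so at this position these two aryl groups are interchangeable within the scatter. Nothing shown gives a cause for this step.

The swap replaces the whole aryl group at once, so the compounds shown do not separate the contribution of the nitro group from that of the carboxylic acid, and neither group is compared with a plain phenyl on the same sulfonyl sulfur. Also open, on these data alone, is whether an amine on the aryl ring, or a longer alkyl chain in place of the ring, would move the number in this assay by a step beyond the scatter.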